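The compounds below may be only part of what the source reports. "The series", "measured", "known", "first", "only" and "open" are said of these compounds alone.

Measured compounds:
- compound 1, `Cc1c(Cl)cccc1-c1cccc(COc2ccc([C@H](CC(=O)O)c3nccn3C)cc2)c1`: 61 nM
- compound 2, `Cc1cc(Cl)ccc1-c1cc(COc2ccc([C@H](CC(=O)O)c3nccn3C)cc2)ccc1C`: 97 nM

In an assay on CHO cells for agonist activity at Free fatty acid receptor 1 (Homo sapiens), read by luminescence, with a stated time of 20 s, in the presence of a further agent that is not named here (a lower number here means that less compound is needed, a higher number that more compound is needed for the effect), compound 1 gives 61 nM, the lower of the two numbers recorded, while compound 2 in this assay gives 97 nM. The two values lie within the scatter of each other, so no order between compound 1 and compound 2 can be read from them.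

The unmeasured compound 3 `COc1ccc(-c2cccc(COc3ccc([C@H](CC(=O)O)c4nccn4C)cc3)c2)cc1` is derived from compound 1 by one change: 4-methoxyphenyl in place of 3-chloro-2-methylphenyl on an aromatic carbon. The distal aryl ring of the biaryl is thus exchanged for one of the same size, trading a chlorine and a methyl for a single methoxy group. Going by the values given here, no step of this kind between measured compounds is available, and the pair of compound 1 and compound 2 speaks only to changes elsewhere on the biaryl. On this basis the step from compound 1 to compound 3 is expected to be modest and toward a higher number, a 3.3-fold higher number from compound 1 to compound 3 (0.52 log units; beyond the scatter), with considerable uncertainty. Compound 3 is therefore estimated at 200 nM in this assay, within a range from 60 nM to 700 nM.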

Compound 3, half-maximal effective concentration: 440 nM
Estimate against measurement, compound 3: 2.2-fold (0.34 log units) below; the range from low to high includes it.
By their numbers in this assay, from the lowest: compounds 1 and 2 (each within the scatter of the next); then compound 3.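

In this assay, going by these compounds alone, exchanging 3-chloro-2-methylphenyl for 4-methoxyphenyl on this aromatic carbon gives a 7.2-fold higher number from compound 1 to compound 3 (0.86 log units; beyond the scatter), the first step that lies beyond the scatter, so the number does respond to the group at this place. The two groups have the same count of heavy atoms and the same six-membered aromatic ring of carbon only, and they differ in the atoms and their arrangement on that ring, with the entering group counted with one hydrogen-bond acceptor and the leaving group with none; matching the heavy-atom count therefore does not preserve the number. No measurement shown here explains the size of this step.

The change removes the chlorine and the methyl and adds the methoxy in a single step, so the compounds shown do not tell which of these parts carries the step. On these data alone, that question stays open for single-change partners of compound 1 and compound 3, such as 2-methylphenyl, 3-chlorophenyl or 4-chlorophenyl at this place, and for other groups on the ring, such as an amine or an ethoxy group.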